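The source may report more compounds than this note shows. Statements on the series, on what has been measured and on what is new or still open speak of the compounds shown alone.

In a functional assay on HeLa cells (Homo sapiens) for inhibition, read by CCK-8 assay, with a stated time of 48 h (on this read-out lower numbers stand for stronger inhibition and higher numbers for weaker inhibition), compound 1 `COc1cc(-c2cc3nccc(-c4c[nH]c5ccccc45)n3n2)cc(OC)c1OC` gives only a limit, > 10000 nM. Compound 3 `Cn1ccc2cc(-c3cc4nccc(-c5ccc(F)cc5)n4n3)ccc21` gives 5210 nM. Compound 2 `COc1cc(-c2ccnc3cc(-c4ccc(Cl)cc4)nn23)cc(OC)c1OC` gives 1490 nM, the lower of the two true numbers, and the gap between them lies beyond the usual scatter. Compound 4 `COc1cc(-c2ccnc3cc(-c4ccc5cc[nH]c5c4)nn23)cc(OC)c1OC` has not yet been measured. It differs from compound 2 in one place, with 1H-indol-6-yl in place of 4-chlorophenyl on an aromatic carbon. Among the compounds with values here, no measured pair of compounds shows this change on its own, so the expectation is loose and its range is wide. The estimated step of a 3.0-fold lower number from compound 2 to compound 4 (0.47 log units; beyond the scatter) is a modest one toward stronger inhibition in this assay. Compound 4 is expected at 500 nM, with an estimated range of 50 nM to 5000 nM.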

Compound 4, half-maximal inhibitory concentration: 125 nM
Compound 4: middle estimate off by 4.0-fold (0.60 log units), on the high side; the range from low to high includes it.
By their numbers in this assay, from the lowest: compound 4; then compound 2; then compound 3. At a limit, above all of these: compound 1.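

Placing 1H-indol-6-yl in place of 4-chlorophenyl on this aromatic carbon gives a 12-fold lower number from compound 2 to compound 4 (1.08 log units; beyond the scatter) in this assay, so this single position can strongly shift the result toward stronger inhibition. The entering group brings both a five-membered aromatic ring and a hydrogen-bond donor, and this one change cannot show which of them matters. No measurement shown here accounts for the size of this step. On these data alone, it remains open whether a 4-aminophenyl or 4-carboxyphenyl group at this position would give a similar step. As far as these compounds go, the effect of a 1-methyl-1H-indol-6-yl group there is also open.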